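A Second Methoxy Group on Compound 3

The compounds below may be only part of what the source reports. "The series", "measured", "known", "first", "only" and "open" are said of these compounds alone.

compound 1, `Cn1cc(-c2nc3ccccc3n2C(=O)c2cccc(Br)c2)c2ccccc21`: 61400 nM
compound 2, `COc1ccc2c(c1)c(-c1nc3ccccc3n1C(=O)c1cccc(Br)c1)cn2C`: 51300 nM
compound 3, `COc1ccc(C(=O)n2c(-c3cn(C)c4ccc(Br)cc34)nc3ccccc32)cc1`: 18900 nM

Three compounds were measured in a functional assay on HepG2 cells (Homo sapiens) for inhibition, read by MTT assay, with a stated time of 24 h; on this read-out higher numbers stand for weaker inhibition of growth and lower numbers for stronger inhibition of growth. Compound 1 `Cn1cc(-c2nc3ccccc3n2C(=O)c2cccc(Br)c2)c2ccccc21` gives 61400 nM. Compound 2 `COc1ccc2c(c1)c(-c1nc3ccccc3n1C(=O)c1cccc(Br)c1)cn2C` differs from it by methoxy in place of hydrogen on an aromatic carbon and gives 51300 nM; the step is a 1.2-fold lower number from compound 1 to compound 2 (0.08 log units; within the scatter). Compound 3 `COc1ccc(C(=O)n2c(-c3cn(C)c4ccc(Br)cc34)nc3ccccc32)cc1` has the lowest number of the three, 18900 nM; how its core differs from the core of compound 1 is not broken down here.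

Compound 4 `COc1ccc(C(=O)n2c(-c3cn(C)c4ccc(Br)cc34)nc3ccccc32)cc1OC` has not been measured. It differs from compound 3 by methoxy in place of hydrogen on an aromatic carbon. Going by the values given here, this is the same kind of change as the one from compound 1 to compound 2, but not the same: there the place was part of a fused or bridged system of two rings, meta to a fused ring and para to a fused ring, whereas here it is ortho to a methoxy group and meta to a large group. Because a 1.2-fold lower number from compound 1 to compound 2 (0.08 log units; within the scatter) lies within the scatter, the step expected from the same change here is small as well: a 1.3-fold lower number from compound 3 to compound 4 (0.10 log units; within the scatter). Compound 4 is therefore estimated at 15000 nM in this assay, between 6000 nM and 40000 nM.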

Compound 4, concentration for 50% growth inhibition: 9700 nM
Compound 4: the middle estimate sits 1.5-fold (0.19 log units) above what was measured, within the range that was stated.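

In this assay the change from 4-methoxyphenyl to 3,4-dimethoxyphenyl gives a 1.9-fold lower number from compound 3 to compound 4 (0.29 log units; within the scatter) and so agrees with the earlier step on the other core: the same change on two cores in this assay, a 1.2-fold lower number (0.08 log units; within the scatter) from compound 1 to compound 2 and a 1.9-fold lower number (0.29 log units; within the scatter) from compound 3 to compound 4, 1.6-fold (0.21 log units) apart, within the scatter of two such steps.

On these two cores, then, methoxy in place of hydrogen on an aromatic carbon gives a step within the scatter each time. Going by these compounds alone, the result rests on only two pairs, with the methoxy at a different place in each, so it does not show that the change has no effect, nor that a step of this size would hold on a further core or at another place.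

The compounds shown leave open whether a hydroxyl, an amine or a longer alkoxy chain in place of the added methoxy would give a step beyond the scatter. They also leave open what a third methoxy group on the same ring would do.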